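Amide substituent series: from compound 2 to compound 3

The source may report more compounds than this note shows. Statements on the series, on what has been measured and on what is new or still open speak of the compounds shown alone.

Of the compounds shown here, two of the shared core have been measured in a functional assay on the whole organism for inhibition, with Rattus norvegicus as the target, read by cytopathic effect and paw edema, at a dose of 100 mg/kg by the oral route; a lower number here means less inhibition, a higher number more inhibition at the dose given (going by the name of the read-out). Compound 1 `CN(C)CCNC(=O)c1c(O)c2cccnc2n(-c2ccccc2)c1=O` gives 18.4%. Compound 2 `Cc1cccc(NC(=O)c2c(O)c3cccnc3n(-c3ccccc3)c2=O)c1` gives 4.5%. Among the measured compounds shown here, the single step so far, a number 13.9 percentage points lower from compound 1 to compound 2 (beyond the scatter), is the only guide to how the amide substituent moves the read-out, and compound 2 stands at the lower of the two numbers, with compound 1 as its only neighbour and separated from it by a gap beyond the scatter.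

Compound 3 `O=C(NCc1ccncc1)c1c(O)c2cccnc2n(-c2ccccc2)c1=O` is the next entry, not yet measured. Its change from compound 2 is (pyridin-4-yl)methyl in place of 3-methylphenyl on an amide-type nitrogen. The step that bears on it is a number 13.9 percentage points lower from compound 1 to compound 2 (beyond the scatter); that step was modest and ran downward when an aromatic ring took the place of a chain bearing a nitrogen. The substituent entering in compound 3 carries a nitrogen-containing ring on a one-carbon link, so a partial return toward the number of compound 1 is expected rather than a further fall, giving an estimated a number 7.5 percentage points higher from compound 2 to compound 3 (within the scatter). For compound 3 the expected value is 12%, within a range from 0% to 28%.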

Compound 3, a percentage reported as inhibition, in the whole organism at one dose (the size of the read-out at that dose, not a potency): 15.4%
For compound 3 the middle estimate is 3.4 percentage points below the measured one; the measured number falls inside the stated range.
By their numbers in this assay, from the lowest: compound 2; then compounds 3 and 1 (each within the scatter of the next).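

In this assay, a number 10.9 percentage points higher from compound 2 to compound 3 (beyond the scatter), so an aromatic ring on the amide-type nitrogen does not by itself bring the low number of compound 2; this single change brings in a ring nitrogen and a saturated chain carbon on the amide-type nitrogen and removes the methyl, and the step cannot be divided among them. The other comparison, a number 3 percentage points lower from compound 1 to compound 3 (within the scatter), shows that at this place pyridin-4-yl and (dimethylamino)methyl on the saturated chain carbon cannot be told apart in this read-out, so an open chain bearing an amine is not the only substituent that stays clear of the number of compound 2. Nothing on hand explains either step.

The compounds shown leave open whether the ring nitrogen or the saturated chain carbon accounts for the step from the number of compound 2, a question that a plain benzyl group or a pyridin-4-yl bound straight to the amide-type nitrogen would address. Also open, going by these compounds, is how this position responds to a longer chain between the amide-type nitrogen and the pyridine ring, or to a carboxylic acid on that chain.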